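A few compounds are considered here, and "the series" means these few. Any claim that something is new, unique, unknown or untested is made for them only; others in the source may bear on it.

Measured so far in an ADME assay on MT4 cells (Homo sapiens) for cytotoxicity, read by MTT assay; a higher number here means that more compound is tolerated, a lower number that less compound is tolerated:
- Compound 1 `O=C1c2ccccc2C(=O)N1CCOC(=S)N(C(=O)c1ccccc1[N+](=O)[O-])c1ccc(Cl)cc1`: 21000 nM
- Compound 2 `O=C1c2ccccc2C(=O)N1CCOC(=S)N(C(=O)c1ccc([N+](=O)[O-])cc1)c1ccc(Cl)cc1`: > 100000 nM, which is a limit of the assay and not a number
- Compound 3 `O=C1c2ccccc2C(=O)N1CCOC(=S)N(C(=O)c1cc(F)ccc1F)c1ccc(Cl)cc1`: 54000 nM

Setting that limit aside, compound 3 holds the higher of the two true numbers, and the step separating them is a 2.6-fold higher number from compound 1 to compound 3 (0.41 log units; beyond the scatter). Compound 4 `O=C1c2ccccc2C(=O)N1CCOC(=S)N(C(=O)c1cccc(Cl)c1Cl)c1ccc(Cl)cc1` keeps the shared core and changes one group: 2,3-dichlorophenyl in place of 2,5-difluorophenyl on a carbonyl carbon. Swaps on this same carbonyl carbon gave an at least 4.7-fold higher number from compound 1 to compound 2 (0.67 log units; beyond the scatter), then a 2.6-fold higher number from compound 1 to compound 3 (0.41 log units; beyond the scatter), and an at least 1.8-fold lower number from compound 2 to compound 3 (0.26 log units; that floor lies within the scatter). None of these compounds carries 2,3-dichlorophenyl, so those modest steps set no direction, and no change beyond the scatter is expected in this assay. The expected change is a 1.4-fold lower number from compound 3 to compound 4 (0.13 log units; within the scatter). For compound 4 the estimate is 40000 nM, with an expected range from 14000 nM to 100000 nM.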

Compound 4, half-maximal cytotoxic concentration: 54000 nM
Beside the measured number, compound 4's estimate is 1.4-fold (0.13 log units) below it, within the range that was stated.
By their numbers in this assay, from the lowest: compound 1; then compounds 3 and 4 (each within the scatter of the next). At a limit, above all of these: compound 2.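

In this assay, 2,3-dichlorophenyl on this carbonyl carbon reads the same as 2,5-difluorophenyl: no change at the digits printed from compound 3 to compound 4 (within the scatter). Measured against 2-nitrophenyl, the new group gives a 2.6-fold higher number from compound 1 to compound 4 (0.41 log units; beyond the scatter), so two differently substituted halogen-bearing rings now both stand apart from compound 1. The value of compound 2 is a limit of the assay and not a number, so its step gives only a floor: an at least 1.8-fold lower number from compound 2 to compound 4 (0.26 log units; that floor lies within the scatter).

The compounds shown leave open whether an amine or a carboxylic acid on this ring would move the number. They also leave open whether a ring with a single chlorine would read the same.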